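The source may report more compounds than this note shows. Statements on the series, on what has been measured and on what is new or still open speak of the compounds shown alone.

The two measured compounds are:

compound 1, `Cc1ccc2c(=O)[nH]c(-c3cccc(F)c3)nc2c1`, giving 4.3% in an assay on isolated protein for inhibition of DNA topoisomerase 1 (Homo sapiens), with a stated time of 30 min, tested at 20 uM; a lower number here means a weaker effect, a higher number a stronger effect of the compound at the concentration tested;
compound 2, `COc1cccc(-c2nc3cc(C)ccc3c(=O)[nH]2)c1`, giving 80% in this assay.

Compound 2 stands highest of the two numbers, and its nearest neighbour is compound 1, which lies lower by a number 75.7 percentage points higher from compound 1 to compound 2 (beyond the scatter), a step beyond the scatter. Compound 3, `Cc1ccc2c(=O)[nH]c(-c3cccc(C(F)(F)F)c3)nc2c1`, has not yet been measured. It differs from compound 2 in one place: trifluoromethyl in place of methoxy on an aromatic carbon. Within the data shown here, only one measured step bears on this change, the exchange at the same aromatic carbon that separates compound 1 from compound 2; it was large, a number 75.7 percentage points higher from compound 1 to compound 2 (beyond the scatter). The trifluoromethyl of compound 3, like the fluoro of compound 1, carries no hydrogen-bond acceptor, while the methoxy it replaces carried one. Among the measured compounds shown here, on that single comparison a drop in this assay is expected from compound 2 to compound 3, though with only one step to lean on its size is uncertain. The step from compound 2 to compound 3 is estimated at a number 60 percentage points lower from compound 2 to compound 3 (beyond the scatter). Compound 3 is therefore expected to give about 20%, within a range of 0% to 55%.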

Compound 3, a percentage reported as inhibition, at one concentration (the size of the read-out at that concentration, not a potency): 93.6%
Compound 3: middle estimate off by 73.6 percentage points, on the low side; measured number above the stated range.
By their numbers in this assay, from the lowest: compound 1; then compound 2; then compound 3.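

At this aromatic carbon, trifluoromethyl in place of methoxy gives a number 13.6 percentage points higher from compound 2 to compound 3 (beyond the scatter) in this assay, so the hydrogen-bond acceptor of the methoxy is not required for a high read-out at this position. The low number of compound 1 therefore cannot be read as the result of lacking such an acceptor, and the sharp divide at this position now lies between fluoro and trifluoromethyl, with a number 89.3 percentage points higher from compound 1 to compound 3 (beyond the scatter) as the largest step among the three compounds. Methoxy and trifluoromethyl, which share neither atoms beyond carbon nor a hydrogen-bond acceptor, both stand far above fluoro, so the hydrogen-bond acceptor count alone does not order the series, and compound 3 is the one that goes against such an ordering.

From the compounds shown here alone, whether the high read-out also holds for an amine, a nitrile or a longer chain such as ethoxy at this carbon remains open, as does the outcome of placing trifluoromethyl elsewhere on the same ring. No measurement at hand accounts for why fluoro differs so strongly from the other two groups.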